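Swapping Bromo for Cyano on a Tryptophan Dioxygenase Inhibitor

The source may report more compounds than this note shows. Statements on the series, on what has been measured and on what is new or still open speak of the compounds shown alone.

For the measured compounds named here, compound 2 `O=[N+]([O-])c1ccccc1CNc1cc(Br)cc2[nH]ncc12` sits at the bottom of the three numbers measured so far. In an assay for inhibition of Tryptophan 2,3-dioxygenase (Homo sapiens), with stated times of 10 min and 60 min, tested at 100 uM (a higher number here means a stronger effect of the compound at the concentration tested, a lower number a weaker effect), compound 2 gives 64%. Compound 1 `O=[N+]([O-])c1ccccc1CNc1cc(C(F)(F)F)cc2[nH]ncc12` carries trifluoromethyl where compound 2 carries bromo, and in this assay compound 1 gives 95%; the step is a number 31 percentage points lower from compound 1 to compound 2 (beyond the scatter). Compound 3 `O=[N+]([O-])c1ccc(O)cc1CNc1cc(Br)cc2[nH]ncc12` has hydroxy in place of hydrogen on an aromatic carbon, and in this assay compound 3 gives 99%; the step is a number 35 percentage points higher from compound 2 to compound 3 (beyond the scatter).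

Compound 4 `N#Cc1cc(NCc2ccccc2[N+](=O)[O-])c2cn[nH]c2c1` is the next compound, and it differs from compound 2 in one place: cyano in place of bromo on an aromatic carbon. Neither measured step tests cyano in place of bromo directly. Going by the values given here, the only step touching the same spot is a number 31 percentage points lower from compound 1 to compound 2 (beyond the scatter), which shows that a change at this spot can move the number by a large amount. Cyano is a third kind of group there, and the measured pairs give no way to say whether it will behave more like trifluoromethyl or like bromo. The expectation is therefore a step of uncertain direction, a number 6 percentage points higher from compound 2 to compound 4 (within the scatter), with wide bounds. Compound 4 is estimated at 70%, expected to lie between 40% and 95%.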

Compound 4, a percentage reported as inhibition, at one concentration (the size of the read-out at that concentration, not a potency): 41%
Compound 4: middle estimate off by 29 percentage points, on the high side; low and high end bracket the measured number.
By their numbers in this assay, from the lowest: compound 4; then compound 2; then compounds 1 and 3 (each within the scatter of the next).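

The position now has three groups to compare, and all three differ by more than the scatter in this assay. Cyano in place of bromo gives a number 23 percentage points lower from compound 2 to compound 4 (beyond the scatter) and cyano in place of trifluoromethyl gives a number 54 percentage points lower from compound 1 to compound 4 (beyond the scatter), so the numbers run from cyano at the bottom through bromo to trifluoromethyl at the top. Bromo therefore sits in the middle of this short series rather than at its low end, as it seemed to when only two groups were known, yet nothing available accounts for this order.

As far as these compounds go, whether hydroxy on the ring carrying the nitro group would raise the number of a cyano compound as it raised that of the bromo compound remains open. For the compounds shown here, also unknown is where a chlorine atom, an amine or a carboxylic acid would fall in this order, and with only three groups tested at a single concentration, the series shows a ranking of these groups but no general rule for the position.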